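A few compounds are considered here, and "the series" means these few. Any claim that something is new, unique, unknown or untested is made for them only; others in the source may bear on it.

Of the compounds shown here, three from one series have been tested so far, all in a functional assay on MDA-MB-231 cells (Homo sapiens) for antiproliferative activity, read by sulforhodamine B assay, with a stated time of 48 h; a higher number here means a weaker inhibitor, a lower number a stronger inhibitor. Compound 1 `COc1ccc2nc(-c3ccc(N/C=C\C(=O)c4ccc(OC)c([N+](=O)[O-])c4)cc3)sc2c1` gives 17600 nM there. Compound 3 `COc1ccc2nc(-c3ccc(N/C=C\C(=O)c4cc(OC)c(OC)c([N+](=O)[O-])c4)cc3)sc2c1` carries one extra group on the ring that bears the nitro group, and compound 3 gives 7610 nM; this change, (methoxy in place of hydrogen on an aromatic carbon), brought a 2.3-fold lower number from compound 1 to compound 3 (0.36 log units; beyond the scatter). Compound 2 `COc1ccc(C(=O)/C=C\Nc2ccc(-c3nc4cc(OC)c(OC)c(OC)c4s3)cc2)cc1[N+](=O)[O-]` has a different core from compound 1, and the difference between the two cores is not broken down here; compound 2 gives 17100 nM, which lies close to the number for compound 1.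

Compound 4 `COc1cc(C(=O)/C=C\Nc2ccc(-c3nc4cc(OC)c(OC)c(OC)c4s3)cc2)cc([N+](=O)[O-])c1OC` has not yet been measured. It is made from compound 2 by methoxy in place of hydrogen on an aromatic carbon, the same change that turned compound 1 into compound 3, placed in the same surroundings. Because of a 2.3-fold lower number from compound 1 to compound 3 (0.36 log units; beyond the scatter), a step of similar size is expected here, and the expectation for the step from compound 2 to compound 4 in this assay is a 2.1-fold lower number from compound 2 to compound 4 (0.33 log units; beyond the scatter). Going by the values given here, the estimate for compound 4 in this assay is therefore 8000 nM, with a range from 4000 nM to 16000 nM, since only one earlier example of this change exists and the two cores differ.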

Compound 4, half-maximal inhibitory concentration: 9800 nM
Estimate against measurement, compound 4: 1.2-fold (0.09 log units) below; measured number inside the range.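

In this assay, the same swap of hydrogen for methoxy on a second core brought a 1.7-fold lower number from compound 2 to compound 4 (0.24 log units; within the scatter), and the two cases can be set side by side: the same change on two cores in this assay, a 2.3-fold lower number (0.36 log units; beyond the scatter) from compound 1 to compound 3 and a 1.7-fold lower number (0.24 log units; within the scatter) from compound 2 to compound 4, 1.3-fold (0.12 log units) apart, within the scatter of two such steps. The two steps are therefore compatible with this change carrying over from the core of compound 1 to the core of compound 2, with a similar size on each. This does not prove that it carries over: taken alone, the step on the second core lies within the usual scatter of repeated measurements, two pairs are a very small sample, and neither pair says why the numbers differ.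

The compounds shown leave open whether a different group in the same place, such as an ethoxy group, a hydroxyl or an amine, would behave as methoxy does. They also leave open whether the nitro group matters for this step, as every compound here carries one.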